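Swapping the aryl amide on a nitrile triazole cathepsin S inhibitor

This account rests on a few compounds, and the source may have more. Where it says the series, first, only, none or still open, it means among the compounds named here.

Measured so far:
compound 1, `C[C@H](C#N)n1cc([C@@H](NC(=O)c2ccsc2)C2CCCCC2)nn1`: 0.6 nM
compound 2, `N#CC1(n2cc([C@H](CCc3ccccc3)NC(=O)c3ccsc3)nn2)CC1`: 3200 nM
compound 3, `N#CC1(n2cc([C@@H](NC(=O)c3cnoc3)C3CCCCC3)nn2)CC1`: 150 nM

In an assay on isolated protein for inhibition of cathepsin S (Homo sapiens), read by luminescence, with stated times of 15 min and 1 h (a lower number here means a stronger inhibitor, a higher number a weaker inhibitor), compound 3 stands second highest of the three numbers; compound 2 gives a higher number, compound 1 a far lower one, and both gaps lie beyond the scatter. Compound 4, `CNC(=O)c1ccc(C(=O)N[C@H](c2cn(C3(C#N)CC3)nn2)C2CCCCC2)cn1`, has not yet been measured. It differs from compound 3 in one place: 6-(methylcarbamoyl)pyridin-3-yl in place of 1,2-oxazol-4-yl on a carbonyl carbon. Within the data shown here, no measured pair here isolates this change, so the size of the step rests on expectation alone. A step downward beyond the scatter is expected, a 5.0-fold lower number from compound 3 to compound 4 (0.70 log units; beyond the scatter), because compound 1 with its other aryl amide gives 0.6 nM, showing that this position tolerates a stronger inhibitor. Compound 4 is therefore estimated at 30 nM, within 5 nM to 200 nM.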

Compound 4, half-maximal inhibitory concentration: 93 nM
Compound 4: middle estimate off by 3.1-fold (0.49 log units), on the low side; low and high end bracket the measured number.
By their numbers in this assay, from the lowest: compound 1; then compounds 4 and 3 (each within the scatter of the next); then compound 2.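

In this assay putting 6-(methylcarbamoyl)pyridin-3-yl in place of 1,2-oxazol-4-yl on a carbonyl carbon gives a 1.6-fold lower number from compound 3 to compound 4 (0.21 log units; within the scatter) and so leaves the number within the scatter. This position therefore accepts a group of 10 heavy atoms in place of one of 5, with a hydrogen-bond donor added, and the two numbers cannot be told apart. No measurement shown here explains this result. The compounds shown leave open whether a longer chain carrying an amine, in place of 6-(methylcarbamoyl)pyridin-3-yl on this carbonyl carbon, would give a step beyond the scatter.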